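A few compounds are considered here, and "the series" means these few. Any claim that something is new, unique, unknown or untested is made for them only; others in the source may bear on it.

Compound 1 `OCCNc1ccc2nnnc(Nc3cccc(OC(F)(F)F)c3)c2n1` gives 42900 nM in a functional assay on LNCaP cells (Homo sapiens) for antiproliferative activity, read by MTT assay, with a stated time of 96 h; a higher number here means a weaker inhibitor, a lower number a stronger inhibitor.
Compound 2 `FC(F)(F)Oc1cccc(Nc2nnnc3ccc(N4CCCC4)nc23)c1` reaches only the limit > 100000 nM in this assay.
Compound 3 `FC(F)(F)Oc1cccc(Nc2nnnc3ccc(NCC4CCNCC4)nc23)c1` gives 11500 nM in this assay.

Among these numbers compound 3 stands lowest; its nearest neighbour is compound 1, separated by a 3.7-fold lower number from compound 1 to compound 3 (0.57 log units; beyond the scatter). Compound 4 `FC(F)(F)Oc1cccc(Nc2nnnc3ccc(Cl)nc23)c1` differs from compound 3 in one place: chloro in place of ((piperidin-4-yl)methyl)amino on an aromatic carbon. The three measured steps all change the same position. Enlarging the group there gave a 3.7-fold lower number from compound 1 to compound 3 (0.57 log units; beyond the scatter) and an at least 8.6-fold lower number from compound 2 to compound 3 (0.93 log units; beyond the scatter), while the ring-closed variant gave an at least 2.3-fold higher number from compound 1 to compound 2 (0.36 log units; beyond the scatter). Since the change to compound 4 strips this position down to a single atom, a higher number is expected in this assay. Compound 4 is therefore expected to give 50000 nM, within 15000 nM to 150000 nM, an estimated step of a 4.3-fold higher number from compound 3 to compound 4 (0.64 log units; beyond the scatter).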

Compound 4, half-maximal inhibitory concentration: 8620 nM
The estimate for compound 4 lay 5.8-fold (0.76 log units) above the measured number; measured number below the stated range.
By their numbers in this assay, from the lowest: compounds 4 and 3 (each within the scatter of the next); then compound 1. At a limit, above all of these: compound 2.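

The step of a 1.3-fold lower number from compound 3 to compound 4 (0.13 log units; within the scatter) shows that a lone chloro, with no ring and no hydrogen-bond donors, matches the far larger ((piperidin-4-yl)methyl)amino, so a large group at this position is not needed for such a number. Chloro also separates from the other two groups, with a 5.0-fold lower number from compound 1 to compound 4 (0.70 log units; beyond the scatter) and an at least 11-fold lower number from compound 2 to compound 4 (1.06 log units; beyond the scatter) as the steps. The second of these rests on a limit, that of compound 2: the limit of > 100000 nM in this assay, at which 1 of the 4 values shown sits.

The compounds shown leave open whether fluoro, methoxy or a primary amine at this position would match chloro. They also leave open whether a longer chain ending in an amine would change the number of compound 3.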